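A few compounds are considered here, and "the series" means these few. Any claim that something is new, unique, unknown or untested is made for them only; others in the source may bear on it.

Measured compounds in an ADME assay on BJ cells (Homo sapiens), read by MTT assay, with a stated time of 72 h; on this read-out lower numbers stand for stronger inhibition and higher numbers for weaker inhibition:

compound 1, `CNc1ncnc2c1c(-c1cccs1)cn2[C@@H]1O[C@H](CO)[C@@H](O)[C@H]1O`, gives > 100000 nM
compound 2, `Nc1nc(N)c2c(-c3cccs3)cn([C@@H]3O[C@H](CO)[C@@H](O)[C@H]3O)c2n1`, gives > 100000 nM
compound 3, `CNc1ncnc2c1c(-c1ccoc1)cn2[C@@H]1O[C@H](CO)[C@@H](O)[C@H]1O`, gives 96300 nM

The value recorded for compound 1 in this assay is a limit of the assay and not a number. The value recorded for compound 2 in this assay is likewise a limit and not a number. Only compound 3 returns a numerical reading, and that reading sits close to the limit of > 100000 nM in this assay, at which 2 of the 3 values shown sit.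

Going by the values given here, the one change made twice is furan-3-yl in place of thiophen-2-yl on an aromatic carbon. From compound 1 to compound 3 it gives an at least 1.0-fold lower number from compound 1 to compound 3 (0.01 log units; that floor lies within the scatter), so the change makes no resolvable difference to the half-maximal inhibitory concentration. The difference between the core of compound 1 and the core of compound 2 is not broken down here.

Compound 4, `Nc1nc(N)c2c(-c3ccoc3)cn([C@@H]3O[C@H](CO)[C@@H](O)[C@H]3O)c2n1`, has not yet been measured in this assay. Among the compounds with values here, it relates to compound 2 by furan-3-yl in place of thiophen-2-yl on an aromatic carbon, the same change as the one from compound 1 to compound 3, at the same place. Because an at least 1.0-fold lower number from compound 1 to compound 3 (0.01 log units; that floor lies within the scatter) is within scatter, the step from compound 2 to compound 4 is expected to be of the same negligible size, a number no higher from compound 2 to compound 4 (the limit leaves the size open). Compound 4 is therefore expected to show 100000 nM in this assay, estimated to fall between 50000 nM and 300000 nM, with a strong chance that only a limit is returned.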

Compound 4, half-maximal inhibitory concentration: > 100000 nM
Compound 4 ended at the assay's limit (the forecaster's own chance of this, stated with the estimate: 65%); the middle value lies on the limit itself.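

In this assay, compound 2 and compound 4 both return a limit and not a number, so no step can be read between them. The readings of the series now cluster at one point: the limit of > 100000 nM in this assay, at which 3 of the 4 values shown sit.

The compounds shown leave open what size of step, if any, furan-3-yl in place of thiophen-2-yl gives on the core of compound 2, since the true values of compound 2 and compound 4 remain unresolved.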